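The compounds below may be only part of what the source reports. "The series", "measured", "known", "first", "only" and "open" are said of these compounds alone.

Three compounds share one core and differ from one another only in the group attached to it. Among the compounds with values here, compound 1 `CCCNc1nc(N)nc2c1ncn2/C=C1/CC1(CO)CO` is the first of them; in an ADME assay on MOLT-3 cells (Homo sapiens) for cytotoxicity, with a stated time of 7 days (on this read-out higher numbers stand for lower toxicity in this test and lower numbers for higher toxicity in this test), compound 1 gives "not determined" (no result reported). Compound 2 `CC(C)CNc1nc(N)nc2c1ncn2/C=C1/CC1(CO)CO` is the second; in this assay compound 2 gives "not determined" (no result reported). Compound 3 `CCCCNc1nc(N)nc2c1ncn2/C=C1/CC1(CO)CO` is the third, and in this assay compound 3 reaches only a limit of the test, > 20000 nM, which is not a number. That single reported value sits at the limit of > 20000 nM in this assay, at which 1 of the 3 values shown sits. Within the data shown here, no step between two measured compounds is available here, and nothing is known about how the group on that carbon moves this read-out.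

Compound 4 `CSc1nc(N)nc2c1ncn2/C=C1/CC1(CO)CO` has not yet been measured. It differs from compound 3 in one place: methylsulfanyl in place of butylamino on an aromatic carbon. With compound 3 already at the limit of the test, the expected step that the limit leaves unreadable from compound 3 to compound 4 is estimated to stay within the usual scatter, in no particular direction. The estimate for compound 4 in this assay is 25000 nM, within a range from 8000 nM to 80000 nM, and it is expected that the test will most likely again report only a limit rather than a number.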

Compound 4, half-maximal cytotoxic concentration: > 20000 nM
Compound 4: only a limit was reported; the forecaster's own chance of this, stated with the estimate: 75%; the middle value is on the limit's open side.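

In this assay, within the data shown here, compound 3 and compound 4 both reach only a limit of the test, which is not a number, so no step between them can be read. The compounds shown leave open how the group on that aromatic carbon moves this read-out, since the only results reported are one shared limit: the limit of > 20000 nM in this assay, at which 2 of the 4 values shown sit.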